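Bromo in Place of Cyclohexyl on the Sulfonamide Aryl

The source may hold more compounds than are shown below. What is called first, only, known or untested is meant among the compounds shown, and "the series" means these compounds.

Compound 3 `O=C1NCCN1c1ccc(S(=O)(=O)Nc2ccc(C3CCCCC3)cc2)cc1` stands at a limit in a functional assay on HT-29 cells (Homo sapiens) for antiproliferative activity, read by sulforhodamine B assay, with a stated time of 48 h; on this read-out higher numbers stand for weaker inhibition and lower numbers for stronger inhibition: compound 3 gives > 1000 nM. Compound 2 `CC(C)Cc1ccc(NS(=O)(=O)c2ccc(N3CCNC3=O)cc2)cc1` also sits at a limit in this assay, where compound 2 gives > 1000 nM. Only compound 1 `CCc1ccccc1NS(=O)(=O)c1ccc(N2CCNC2=O)cc1` yields a number, giving 240 nM in this assay. Going by the values given here, the single step that touches compound 3, a step that the two limits leave unreadable from compound 2 to compound 3, cannot be read, since both ends rest on (the limit of > 1000 nM in this assay, at which 2 of the 3 values shown sit).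

Compound 4 `O=C1NCCN1c1ccc(S(=O)(=O)Nc2ccc(Br)cc2)cc1` differs from compound 3 by bromo in place of cyclohexyl on an aromatic carbon. Among the compounds with values here, no measured step bears on this change, and the two limits offer no size to lean on. The account therefore expects compound 4 to land in this assay at an estimated 600 nM, within 150 nM to 2500 nM, which would mean an expected at least 1.6-fold lower number from compound 3 to compound 4 (0.22 log units; that floor lies within the scatter).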

Compound 4, half-maximal inhibitory concentration: 300 nM
Beside the measured number, compound 4's estimate is 2.0-fold (0.30 log units) above it; measured number inside the range.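

This position on the sulfonamide aryl now shows a readable change in this assay: bromo in place of cyclohexyl gives an at least 3.3-fold lower number from compound 3 to compound 4 (0.52 log units; beyond the scatter), and bromo in place of isobutyl gives an at least 3.3-fold lower number from compound 2 to compound 4 (0.52 log units; beyond the scatter). Both sizes are only floors because their starting values are limits: the limit of > 1000 nM in this assay, at which 2 of the 4 values shown sit. Exchanging 2-ethylphenyl for 4-bromophenyl on the sulfonamide nitrogen gives a 1.3-fold higher number from compound 1 to compound 4 (0.10 log units; within the scatter), so these two aryl groups are not separated.

The compounds shown leave open whether an amine or a carboxylic acid at this place would match bromo. Going by these compounds, the true distance between the two limit compounds and compound 4 also remains open.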